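The source may hold more compounds than are shown below. What is called first, only, known or untested is meant among the compounds shown, and "the series" means these compounds.

Compound 1 `C[C@@H]1CCC[C@H](C)N1Cc1cc2c(N)nc(-c3ccc(C(F)F)o3)nc2s1` and compound 2 `Nc1nc(-c2ccc(C(F)F)o2)nc2sc(CN3CCC(F)CC3)cc12` share one core. In an assay on CHO-K1 cells for antagonist activity at adenosine receptor A1 (Homo sapiens), read by a beta-galactosidase reporter, with stated times of 15 min and 6 h (a lower number here means a stronger inhibitor, a higher number a weaker inhibitor), compound 1 gives 730 nM, and compound 2 gives 1670 nM, the higher of the two numbers; the step of a 2.3-fold higher number from compound 1 to compound 2 (0.36 log units; beyond the scatter) is modest. Compound 3 `Nc1nc(-c2cccc([N+](=O)[O-])c2)nc2sc(CN3CCC(F)CC3)cc12` departs from compound 2 at a different place: 3-nitrophenyl in place of 5-(difluoromethyl)furan-2-yl on an aromatic carbon. Among the measured compounds shown here, no measured step touches that aromatic carbon, and the lone step a 2.3-fold higher number from compound 1 to compound 2 (0.36 log units; beyond the scatter) concerns only the group on the saturated chain carbon, so it gives no direct guide. Compound 3 is therefore expected to stay near the same level, estimated at 2000 nM within 500 nM to 8000 nM. The expected step is a 1.2-fold higher number from compound 2 to compound 3 (0.08 log units; within the scatter), well inside a wide uncertainty.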

Compound 3, inhibition constant: > 10000 nM
Compound 3: a limit, no number; the forecaster's own chance of this, stated with the estimate: 10%; middle value at least 5.0-fold (0.69 log units) away from the limit.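

In this assay the aromatic carbon between two ring nitrogen atoms proves sensitive, which the earlier pair, changed only on the saturated chain carbon, could not show: 3-nitrophenyl in place of 5-(difluoromethyl)furan-2-yl gives an at least 5.9-fold higher number from compound 2 to compound 3 (0.77 log units; beyond the scatter) at this carbon. Compound 3 stands at a limit and not at a number, and the step has no upper end: the limit of > 10000 nM in this assay, at which 1 of the 3 values shown sits. The compounds shown leave open whether the loss goes with the departure of the furan ring or the arrival of the nitro group, and a plain phenyl or a 3-aminophenyl at this carbon would separate the two.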